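Moving the chlorine on the longer sulfamide chain

This account rests on a few compounds, and the source may have more. Where it says the series, first, only, none or still open, it means among the compounds named here.

Compound 1 `NS(=O)(=O)NCC1CCN(c2cc(-c3ccc(Cl)cc3)ncn2)CC1` and compound 2 `NS(=O)(=O)NCC1CCN(c2cc(-c3cccc(Cl)c3)ncn2)CC1` were both run in a functional assay on M21 cells (Homo sapiens) for antiproliferative activity, read by sulforhodamine B assay, with a stated time of 48 h; a lower number here means a stronger inhibitor of growth, a higher number a weaker inhibitor of growth. In that assay compound 1 gives 50300 nM, and compound 2 gives 62500 nM. The difference between them is 3-chlorophenyl in place of 4-chlorophenyl on an aromatic carbon, and this change made a 1.2-fold higher number from compound 1 to compound 2 (0.09 log units; within the scatter). Compound 3 `NS(=O)(=O)NCCC1CCN(c2cc(-c3ccc(Cl)cc3)ncn2)CC1` differs from compound 1 in its core by (sulfamoylamino)methyl in place of sulfamoylamino on a saturated chain carbon bound to a saturated ring carbon, which made a 1.1-fold lower number from compound 1 to compound 3 (0.05 log units; within the scatter); in this assay compound 3 gives 45200 nM. Compound 4 `NS(=O)(=O)NCCC1CCN(c2cc(-c3cccc(Cl)c3)ncn2)CC1` has not yet been measured in this assay. It differs from compound 3 by 3-chlorophenyl in place of 4-chlorophenyl on an aromatic carbon, the same change as that from compound 1 to compound 2, here made on the core of compound 3. Because the earlier change gave a 1.2-fold higher number from compound 1 to compound 2 (0.09 log units; within the scatter), the expected step for compound 4 is a 1.2-fold higher number from compound 3 to compound 4 (0.09 log units; within the scatter). That expectation rests on a single measured pair, so the range is kept wide. In this assay compound 4 is estimated at 55000 nM, with the number expected to fall between 25000 nM and 120000 nM.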

Compound 4, concentration for 50% growth inhibition: 50700 nM
For compound 4 the middle estimate is 1.1-fold (0.04 log units) above the measured one; the range from low to high includes it.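

In this assay, 3-chlorophenyl in place of 4-chlorophenyl made a 1.1-fold higher number from compound 3 to compound 4 (0.05 log units; within the scatter), which agrees with the same change on the shorter chain: the same change on two cores in this assay, a 1.2-fold higher number (0.09 log units; within the scatter) from compound 1 to compound 2 and a 1.1-fold higher number (0.05 log units; within the scatter) from compound 3 to compound 4, 1.1-fold (0.04 log units) apart, within the scatter of two such steps. Likewise, (sulfamoylamino)methyl in place of sulfamoylamino made a 1.2-fold lower number from compound 2 to compound 4 (0.09 log units; within the scatter), which agrees with the same change on the 4-chlorophenyl core: the same change on two cores in this assay, a 1.1-fold lower number (0.05 log units; within the scatter) from compound 1 to compound 3 and a 1.2-fold lower number (0.09 log units; within the scatter) from compound 2 to compound 4, 1.1-fold (0.04 log units) apart, within the scatter of two such steps. Among these compounds, all four steps lie within the scatter, so the series shows only that neither change gave a measurable shift on either core; it does not show that a real effect carries from one core to another, and it covers only these two cores for each change.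

All four compounds carry a chlorine on the phenyl ring, which leaves open what a fluorine, a methoxy group or a bare phenyl would do in this assay. From the compounds shown here alone, it also remains open whether a longer chain, or an amine or a carboxylic acid in place of the sulfamide, would move the number beyond the scatter.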